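The compounds below may be only part of what the source reports. "The series", "measured", "known", "first", "only" and "open" are said of these compounds alone.

In a functional assay on HCT-116 cells (Homo sapiens) for inhibition, read by colorimetric assay, with a stated time of 3 days (on this read-out lower numbers stand for stronger inhibition and higher numbers for weaker inhibition), compound 1 `O=C(CCCCCCNC(=O)C(O)(O)C(F)(F)F)Nc1nccs1` gives 10800 nM. Compound 3 `O=C(CCCCCCNC(=O)C(O)(O)C(F)(F)F)Nc1nc2ccccc2s1` gives 2370 nM. Compound 2 `NC(=O)C(=O)NCCCCC(=O)Nc1ccccc1` reaches only the limit of this assay, > 100000 nM.

Compound 2 thus stands at the weak end of the three, at a limit rather than a number (the limit of > 100000 nM in this assay, at which 1 of the 3 values shown sits). Compound 4 `O=C(CCCCNC(=O)c1cc(=O)c(O)co1)Nc1ccccc1` differs from it by a group of 8 heavy atoms (5 carbon, 3 oxygen; one six-membered aromatic ring with 1 hetero atom) in place of a group of 3 heavy atoms (1 carbon, 1 nitrogen, 1 oxygen; no ring), on a carbonyl carbon. Among the compounds with values here, the only measured step, a 4.6-fold lower number from compound 1 to compound 3 (0.66 log units; beyond the scatter), concerns the aryl group on the amide-type nitrogen, not the carbonyl carbon where compound 4 changes; no measured step bears directly on this change. With only a limit as the starting point, compound 4 is expected to move by an at least 2.5-fold lower number from compound 2 to compound 4 (0.39 log units; beyond the scatter) into the measurable range, and its estimate is 40000 nM, within 8000 nM to 200000 nM.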

Compound 4, half-maximal inhibitory concentration: > 100000 nM
Compound 4 gave a limit, no number; the forecaster's own chance of this, stated with the estimate: 45%; at least 2.5-fold (0.39 log units) between middle value and limit.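

Within the data shown here, compound 2 and compound 4 both stand at a limit in this assay, so no step between them can be read: the limit of > 100000 nM in this assay, at which 2 of the 4 values shown sit. The compounds shown leave open whether the ring-bearing group in place of carbamoyl on the carbonyl carbon changes inhibition at all.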